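The source may hold more compounds than are shown below. What is called first, only, known or untested is meant among the compounds shown, and "the series" means these compounds.

Compound 1, with the structure `Cc1ccc(NC2=CC(=O)c3c(nc4n3[C@H]3OC[C@@H](O)[C@H]3OC4)C2=O)cc1C`, is the reference point of this account. In a functional assay on MCF7 cells (Homo sapiens) for inhibition, read by sulforhodamine B assay (on this read-out lower numbers stand for stronger inhibition and higher numbers for weaker inhibition), compound 1 gives 4950 nM, the lowest of the two numbers recorded, and its nearest neighbour is compound 2, whose structure is `O=C1C=C(Nc2cccc(F)c2)C(=O)c2c1nc1n2[C@H]2OC[C@@H](O)[C@H]2OC1` and which gives 5500 nM in this assay, a gap that sits within the scatter. Compound 3, with the structure `CCCN(CCC)C1=CC(=O)c2nc3n(c2C1=O)[C@H]1OC[C@@H](O)[C@H]1OC3`, reaches only a limit of this assay, > 16000 nM. Among the measured compounds shown here, the one step measured between neighbours is an at least 2.9-fold higher number from compound 2 to compound 3 (0.46 log units; beyond the scatter), and the relevant evidence on that step is the limit of > 16000 nM in this assay, at which 1 of the 3 values shown sits.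

Compound 4, with the structure `COc1cccc(NC2=CC(=O)c3c(nc4n3[C@H]3OC[C@@H](O)[C@H]3OC4)C2=O)c1`, is not yet measured. It differs from compound 1 by 3-methoxyphenyl in place of 3,4-dimethylphenyl on an amine nitrogen. For the measured compounds named here, the only measured step exchanges an arylamino group for dipropylamino, a different kind of change from the one between compound 1 and compound 4, so it bears on the new step only loosely. Compound 1 and compound 2, which differ in the substituent on the arylamino ring, sit within the scatter of each other, so a change of ring substituent is expected to move the number little. The step from compound 1 to compound 4 is therefore expected to be a 1.0-fold higher number from compound 1 to compound 4 (0.00 log units; within the scatter), no change beyond the scatter. Compound 4 is estimated to give 5000 nM, between 2200 nM and 12000 nM.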

Compound 4, half-maximal inhibitory concentration: 3830 nM
Compound 4: the middle estimate sits 1.3-fold (0.12 log units) above what was measured; the measured number falls inside the stated range.
By their numbers in this assay, from the lowest: compounds 4, 1 and 2 (each within the scatter of the next). At a limit, above all of these: compound 3.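

In this assay, the step from the 3,4-dimethylphenyl to the 3-methoxyphenyl group on the amine nitrogen is a 1.3-fold lower number from compound 1 to compound 4 (0.11 log units; within the scatter), so this exchange leaves the number where it was. The earlier compounds shown here carried only a carbon-only ring with methyl groups or a fluorine-bearing ring at this position, whereas 3-methoxyphenyl brings an oxygen and a hydrogen-bond acceptor that 3,4-dimethylphenyl lacks, and neither addition moves the number beyond the scatter. Nothing shown here explains why the number stays put under this change.

The compounds shown leave open whether a ring bearing an amine or a carboxylic acid, or a pyridine ring in place of the phenyl ring, would shift the number in this assay any more than the methoxy group does. Among the compounds shown here, they also leave open how a single short chain on the amine nitrogen, such as ethylamino, or a benzylamino group would compare with the arylamino compounds, since the only non-aryl group here is the dipropylamino of compound 3.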